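A few compounds are considered here, and "the series" means these few. Any claim that something is new, unique, unknown or untested is made for them only; others in the source may bear on it.

Going by the values given here, compound 1 `COc1ccc(-c2noc(NC(=O)c3ccc(F)cc3)c2C)cc1` is the first of three compounds examined in a toxicity assay on THP-1 cells (Homo sapiens) for inhibition; a higher number here means that more compound is tolerated, a lower number that less compound is tolerated. In this assay compound 1 gives > 100000 nM, which is a limit of the assay rather than a number. Compound 2 `COc1ccc(-c2cnc(NC(=O)c3cccc(C#N)c3)n2C)cc1` is the starting point of the step followed here. In this assay compound 2 gives > 100000 nM, again a limit and not a number. Compound 3 `COc1ccc(-c2cccc(NC(=O)c3ccc(F)cc3)n2)cc1` in this assay gives > 100000 nM, also a limit. The picture so far is uniform: the limit of > 100000 nM in this assay, at which 3 of the 3 values shown sit. Compound 4 `COc1ccc(-c2cnc(NC(=O)c3ccncc3)n2C)cc1` is not yet measured; it differs from compound 2 by pyridin-4-yl in place of 3-cyanophenyl on a carbonyl carbon. Among the compounds with values here, with no measured step available, the step of a number no higher from compound 2 to compound 4 (the limit leaves the size open) is expected to be none beyond the scatter, leaving compound 4 at the same limit. Compound 4 is thus estimated at 100000 nM in this assay, within 50000 nM to 200000 nM.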

Compound 4, half-maximal cytotoxic concentration: > 100000 nM
Compound 4: no number, only a limit; the forecaster's own chance of this, stated with the estimate: 85%; the middle value sits exactly at the limit.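

Compound 2 and compound 4 each give only a limit in this assay, so no step can be read between them. The compounds shown leave open whether any of them differ in tolerated concentration, with every value resting on the same limit: the limit of > 100000 nM in this assay, at which 4 of the 4 values shown sit.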